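Swapping a Fluorophenyl Ester for a Nitrofuran Ester

This account rests on a few compounds, and the source may have more. Where it says the series, first, only, none or still open, it means among the compounds named here.

Compound 1 `CC1=CC[C@H]2[C@@H]1CC=C(C)[C@@H](CC[C@H]1[C@]3(C)CC[C@H](OC(=O)c4ccccc4)C(C)(C)O[C@H]3CC[C@@]1(C)O)C2(C)C` gives 23100 nM in this series.
Compound 2 `CC1=CC[C@H]2[C@@H]1CC=C(C)[C@@H](CC[C@H]1[C@]3(C)CC[C@H](OC(=O)c4ccc(C)cc4)C(C)(C)O[C@H]3CC[C@@]1(C)O)C2(C)C` sits at a limit of the assay, > 50000 nM.
Compound 3 `CC1=CC[C@H]2[C@H](CC[C@]2(C)O)C(C)(C)[C@@H]1CC[C@H]1[C@]2(C)CC[C@H](OC(=O)c3ccc(F)cc3)C(C)(C)O[C@H]2CC[C@@]1(C)O` gives 33500 nM.

All three are esters of a shared core, differing only in the group on the carbonyl carbon. In a functional assay on MCF7 cells (Homo sapiens) for antiproliferative activity, read by MTT assay, with a stated time of 72 h (a lower number here means a stronger inhibitor, a higher number a weaker inhibitor), compound 1 gives 23100 nM. Compound 2 reaches only the limit of the assay, > 50000 nM. Compound 3 gives 33500 nM, the higher of the two plain numbers, with compound 1 nearest to it and within the scatter, so the two cannot be ranked.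

Among the compounds with values here, the one measured step is an at least 2.1-fold higher number from compound 1 to compound 2 (0.33 log units; beyond the scatter); compound 2 there stands at the limit of > 50000 nM in this assay, at which 1 of the 3 values shown sits, so its true size is unknown beyond the limit.

Compound 4 `CC1=CC[C@H]2[C@H](CC[C@]2(C)O)C(C)(C)[C@@H]1CC[C@H]1[C@]2(C)CC[C@H](OC(=O)c3ccc([N+](=O)[O-])o3)C(C)(C)O[C@H]2CC[C@@]1(C)O` differs from compound 3 by 5-nitrofuran-2-yl in place of 4-fluorophenyl on a carbonyl carbon. Within the data shown here, no measured step touches this exchange: the measured step concerns a methyl on a benzene ring, not the replacement of one aromatic ring by another. The expectation therefore rests on the weak and narrow spread of compounds 1 and 3, and compound 4 is expected to stay near compound 3, a step of a 1.1-fold lower number from compound 3 to compound 4 (0.05 log units; within the scatter). Compound 4 is estimated at 30000 nM, between 10000 nM and 60000 nM.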

Compound 4, half-maximal inhibitory concentration: 21300 nM
The estimate for compound 4 lay 1.4-fold (0.15 log units) above the measured number; measured number inside the range.
By their numbers in this assay, from the lowest: compounds 4, 1 and 3 (each within the scatter of the next). At a limit, above all of these: compound 2.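

In this assay, putting 5-nitrofuran-2-yl in place of 4-fluorophenyl on the carbonyl carbon gives a 1.6-fold lower number from compound 3 to compound 4 (0.20 log units; within the scatter), so the two compounds cannot be ranked. The earlier step only added a methyl to a benzene ring, whereas here the whole six-membered aromatic ring is exchanged for a five-membered one that also brings hydrogen-bond acceptors, which 4-fluorophenyl lacks, and the number still stays within the scatter. Nothing measured among these compounds gives a reason for this result.

This calm response holds for this pair alone, and compound 2, with its methyl on the benzene ring, stands at a limit of the assay, > 50000 nM, which goes against any general claim that this position accepts every aromatic group. From the compounds shown here alone, what stays open is whether the ester group can leave the aromatic family altogether, for example whether an amine, a carboxylic acid or a longer saturated carbon chain on the carbonyl carbon would give a number in the same range.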